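This account rests on a few compounds, and the source may have more. Where it says the series, first, only, none or still open, it means among the compounds named here.

Of the compounds shown here, three have so far been measured in a functional assay on BT-474 cells (Homo sapiens) for antiproliferative activity, read by MTT assay, with a stated time of 72 h; on this read-out lower numbers stand for stronger inhibition and higher numbers for weaker inhibition. Compound 1 `CC(Oc1ncnc2ccc(-c3cnn(C4CCNCC4)c3)cc12)c1c(Cl)ccc(F)c1Cl` gives 4140 nM in that assay. Compound 3 `CC(Oc1ncnc2ccc(-c3cnn(C)c3)cc12)c1c(Cl)ccc(F)c1Cl` differs from compound 1 by methyl in place of piperidin-4-yl on an aromatic nitrogen; in this assay compound 3 gives 45600 nM, and the step is an 11-fold higher number from compound 1 to compound 3 (1.04 log units; beyond the scatter). Compound 2 `c1cnc2ccc(Nc3ncnc4ccc(-c5cnn(C6CCNCC6)c5)cc34)cc2c1` carries the same piperidin-4-yl on an aromatic nitrogen as compound 1, but the difference between the two cores is not broken down here; in this assay compound 2 gives 12900 nM, a higher number than compound 1 and a lower one than compound 3. Compound 4 `Cn1cc(-c2ccc3ncnc(Nc4ccc5ncccc5c4)c3c2)cn1` has not yet been measured. It differs from compound 2 by methyl in place of piperidin-4-yl on an aromatic nitrogen, the same change as from compound 1 to compound 3, at the same place. Because the earlier pair moved by an 11-fold higher number from compound 1 to compound 3 (1.04 log units; beyond the scatter), a step in the same direction is expected here, estimated as a 7.0-fold higher number from compound 2 to compound 4 (0.84 log units; beyond the scatter), though the core of compound 2 is different and a smaller step cannot be excluded. Compound 4 is therefore expected to give about 90000 nM in this assay, with a likely range from 25000 nM to 300000 nM.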

Compound 4, half-maximal inhibitory concentration: 10900 nM
Compound 4: middle estimate off by 8.3-fold (0.92 log units), on the high side; measured number outside the range, below it.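

In this assay, placing methyl instead of piperidin-4-yl on the core of compound 2 gives a 1.2-fold lower number from compound 2 to compound 4 (0.07 log units; within the scatter), so compound 2 and compound 4 cannot be told apart. The same change therefore does not carry over in size from the core of compound 1 to the core of compound 2: the same change on two cores in this assay, an 11-fold higher number (1.04 log units; beyond the scatter) from compound 1 to compound 3 and a 1.2-fold lower number (0.07 log units; within the scatter) from compound 2 to compound 4, 13-fold (1.12 log units) apart, beyond the scatter of two such steps This shows that, for these two pairs, the result of the change depends on the core it is made on, so a step seen on one core is a poor guide to the other; it rests on two pairs only and does not show which feature of the two cores is responsible.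

The compounds shown leave open whether another group on that aromatic nitrogen, such as a longer chain ending in an amine or a carboxylic acid, would also separate the two cores. They also leave open how the change would behave on any third core.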